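The source may hold more compounds than are shown below. What is called first, only, known or untested is meant among the compounds shown, and "the series" means these compounds.

In a functional assay on MKN-45 cells (Homo sapiens) for antiproliferative activity, read by CellTiter-Glo, with a stated time of 3 days (a higher number here means a weaker inhibitor, a lower number a stronger inhibitor), three compounds built on one shared core have been measured, and they differ in the group on an aromatic carbon. Compound 1 `C[C@@H](Oc1c(N)ncc2c(-c3cn[nH]c3)coc12)c1c(Cl)ccc(F)c1Cl`, with a 1H-pyrazol-4-yl group, gives 3300 nM. Compound 2 `C[C@@H](Oc1c(N)ncc2c(-c3ccncc3)coc12)c1c(Cl)ccc(F)c1Cl`, with a pyridin-4-yl group, gives 900 nM. Compound 3 `CC(=O)N1CC=C(c2coc3c(O[C@H](C)c4c(Cl)ccc(F)c4Cl)c(N)ncc23)CC1`, with an acetyl-bearing six-membered non-aromatic ring, gives 330 nM, the lowest number of the three. The measured steps are a 3.7-fold lower number from compound 1 to compound 2 (0.56 log units; beyond the scatter), a 10-fold lower number from compound 1 to compound 3 (1.00 log units; beyond the scatter) and a 2.7-fold lower number from compound 2 to compound 3 (0.44 log units; beyond the scatter).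

Compound 4 `COC(=O)N1CC=C(c2coc3c(O[C@H](C)c4c(Cl)ccc(F)c4Cl)c(N)ncc23)CC1` differs from compound 3 in one place: methoxy in place of methyl on a carbonyl carbon. In words, this is methoxy in place of methyl on a carbonyl carbon, or acetyl to methoxycarbonyl. Among the measured compounds shown here, none of the measured steps touches this place, since each exchanges the whole group on the aromatic carbon. For the measured compounds named here, they therefore bear on it only loosely, and the data hold no direct precedent for the change. Going by the values given here, with no measured step pointing either way, no shift beyond the scatter is expected in this assay, and the estimate stays close to compound 3 at 330 nM. The expected outcome is a 1.1-fold lower number from compound 3 to compound 4 (0.04 log units; within the scatter). Compound 4 is estimated at 300 nM, with an expected range of 120 nM to 750 nM.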

Compound 4, half-maximal inhibitory concentration: 850 nM
Compound 4: the middle estimate sits 2.8-fold (0.45 log units) below what was measured, outside the stated range (above it).
By their numbers in this assay, from the lowest: compound 3; then compounds 4 and 2 (each within the scatter of the next); then compound 1.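

Among the compounds shown here, on the carbonyl carbon whose other neighbour is the amide-type nitrogen in a ring, the number in this assay responds to a small exchange: acetyl to methoxycarbonyl gives a 2.6-fold higher number from compound 3 to compound 4 (0.41 log units; beyond the scatter) and so moves it beyond the scatter, something the earlier steps could not show since each replaced the whole group on the aromatic carbon. The gap that separated compound 3 from compound 2 is gone with this change, as the listed step reads a 1.1-fold lower number from compound 2 to compound 4 (0.02 log units; within the scatter) and places the two within the scatter of each other, while the comparison with the pyrazole compound still reads a 3.9-fold lower number from compound 1 to compound 4 (0.59 log units; beyond the scatter) and stays beyond the scatter. Nothing measured here accounts for the difference between methyl and methoxy at this carbon.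

Only methyl and methoxy are shown on this carbonyl carbon, so it remains open how a dimethylamino group, an ethoxy group or a longer chain such as propyl would read there. On these data alone, it also remains open whether methoxy in place of methyl would give a step of similar size on a different group at the aromatic carbon.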